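A Pyridyl Replaces the Sulfonylphenyl of Compound 3

The source may hold more compounds than are shown below. What is called first, only, known or untested is meant among the compounds shown, and "the series" means these compounds.

Compound 3, `C[C@@H]1CN(C(=O)OC(C)(C)C)CCN1c1ncc(OCc2ccc(S(C)(=O)=O)cc2F)cn1`, gives 149% in an in vitro functional assay on HEK293S cells with Glucose-dependent insulinotropic receptor (Homo sapiens) as the target, read by HTRF and cAMP accumulation, with a stated time of 45 min (a lower number here means a smaller maximal response, a higher number a larger maximal response), the highest of the three measured values. Compound 1, `C[C@@H]1CN(C(=O)OC(C)(C)C)CCN1c1ncc(OCC2CCN(S(C)(=O)=O)CC2)cn1`, gives 99% and compound 2, `C[C@@H]1CN(C(=O)OC(C)(C)C)CCN1c1ncc(OCc2ccc(-n3cnnn3)cc2)cn1`, gives 89%; the steps of a number 50 percentage points higher from compound 1 to compound 3 (beyond the scatter) and a number 60 percentage points higher from compound 2 to compound 3 (beyond the scatter) show that the group on the saturated chain carbon bound to the oxygen moves the response strongly, whereas a number 10 percentage points lower from compound 1 to compound 2 (within the scatter) stays within the scatter. Compound 4, `Cc1cnccc1COc1cnc(N2CCN(C(=O)OC(C)(C)C)C[C@H]2C)nc1`, carries 3-methylpyridin-4-yl in place of 2-fluoro-4-(methylsulfonyl)phenyl on a saturated chain carbon bound to an oxygen on an aromatic ring. Both other groups measured at this place gave far smaller responses than the group of compound 3, so a downward step of similar size is expected for compound 4, a number 49 percentage points lower from compound 3 to compound 4 (beyond the scatter). Compound 4 is therefore estimated at 100%, with a range from 75% to 130%.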

Compound 4, intrinsic activity: the largest response reached, in percent of the reference agonist's: 68%
Estimate against measurement, compound 4: 32 percentage points above; the whole stated range lies above it.
By their numbers in this assay, from the lowest: compound 4; then compounds 2 and 1 (each within the scatter of the next); then compound 3.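

In this assay, 3-methylpyridin-4-yl gives the lowest response among the four groups at this place: a number 81 percentage points lower from compound 3 to compound 4 (beyond the scatter), a number 21 percentage points lower from compound 2 to compound 4 (beyond the scatter) and a number 31 percentage points lower from compound 1 to compound 4 (beyond the scatter). A six-membered aromatic ring on this carbon therefore does not by itself set the response, as compound 3 and compound 4 both carry one. No measurement shown here accounts for the drop.

The change swaps the fluorine, the methylsulfonyl, the ring nitrogen and the methyl together, and the compounds shown do not separate their contributions. A plain phenyl or a 4-(methylsulfonyl)phenyl without the fluorine at this place remains an open comparison.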